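Swapping the phenyl substituent on the triazole nitrogen

A few compounds are considered here, and "the series" means these few. Any claim that something is new, unique, unknown or untested is made for them only; others in the source may bear on it.

Measured compounds:
Compound 1, `O=C(Nc1cccc(OCc2cn(-c3ccccc3)nn2)c1)Nc1ccc(Cl)c(C(F)(F)F)c1`, 1780 nM
Compound 2, `N#Cc1ccccc1-n1cc(COc2cccc(NC(=O)Nc3ccc(Cl)c(C(F)(F)F)c3)c2)nn1`, 1970 nM
Compound 3, `O=C(Nc1cccc(OCc2cn(-c3cccc(F)c3)nn2)c1)Nc1ccc(Cl)c(C(F)(F)F)c1`, 2120 nM

The three compounds share one core and differ only in the group carried on an aromatic nitrogen of a five-membered aromatic ring with 3 nitrogen. In a functional assay on HepG2 cells (Homo sapiens) for inhibition, read by MTT assay, with a stated time of 72 h (on this read-out lower numbers stand for stronger inhibition and higher numbers for weaker inhibition), compound 2 stands second highest of the three numbers, yet its neighbours lie within the scatter on both sides: a 1.1-fold higher number from compound 1 to compound 2 (0.04 log units; within the scatter), and a 1.1-fold higher number from compound 2 to compound 3 (0.03 log units; within the scatter). The third step, a 1.2-fold higher number from compound 1 to compound 3 (0.08 log units; within the scatter), is equally small. In short, hydrogen, cyano and fluoro on that phenyl ring give numbers that cannot be told apart.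

Compound 4, `O=C(Nc1cccc(OCc2cn(-c3cccc(C(F)(F)F)c3)nn2)c1)Nc1ccc(Cl)c(C(F)(F)F)c1`, is not yet measured. It differs from compound 2 as follows: 3-(trifluoromethyl)phenyl in place of 2-cyanophenyl on an aromatic nitrogen. The step most like this one is the swap from compound 2 to compound 3, where one phenyl substituent replaced another without a change beyond the scatter. The two other steps point the same way. With nothing in the measured set suggesting that this part of the molecule moves the read-out, no step beyond the scatter is expected in this assay.

Compound 4 is therefore expected to give about 2100 nM, with a likely range from 1100 nM to 4200 nM. The expected step, a 1.1-fold higher number from compound 2 to compound 4 (0.03 log units; within the scatter), is essentially none.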

Compound 4, half-maximal inhibitory concentration: 1270 nM
Beside the measured number, compound 4's estimate is 1.7-fold (0.22 log units) above it, and the stated range covers the measured number.
By their numbers in this assay, from the lowest: compounds 4, 1, 2 and 3 (each within the scatter of the next).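

In this assay, a trifluoromethyl group on the phenyl ring leaves the number within the scatter of all three earlier compounds: a 1.6-fold lower number from compound 2 to compound 4 (0.19 log units; within the scatter), a 1.7-fold lower number from compound 3 to compound 4 (0.22 log units; within the scatter), and a 1.4-fold lower number from compound 1 to compound 4 (0.15 log units; within the scatter). The earlier compounds shown here carried only a cyano group, a single fluoro or plain hydrogen on this ring, so the flat picture now extends to a larger substituent, and the comparison with compound 3 shows that growing fluoro into trifluoromethyl at the same ring position does not separate the two compounds. Nothing at hand explains why such different substituents give numbers that cannot be told apart.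

From the compounds shown here alone, all four compounds keep a phenyl ring on the triazole nitrogen and carry only small, uncharged substituents on it, so it remains open whether the read-out would hold with a carboxylic acid or a dimethylamino group on that ring, or with a longer alkyl chain in place of the ring itself. The shared core is also the same throughout, so these compounds say nothing about how changes elsewhere in the molecule would affect the read-out.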